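The source may report more compounds than this note shows. Statements on the series, on what has been measured and on what is new or still open speak of the compounds shown alone.

Measured compounds:
compound 1 `C/N=C(\NC#N)Nc1cccnc1` — in a functional assay on the whole organism (blood, strain Wistar-Okamoto) with Rattus norvegicus as the target, with a stated time of 5 days (a lower number here means that less compound is needed, a higher number that more compound is needed for the effect), compound 1 gives > 50 mg/kg, which is a limit of the assay, (the limit of > 50 mg/kg in this assay, at which 1 of the 3 values shown sits).
compound 2 `CCC/N=C(\NC#N)Nc1cccnc1` — in this assay compound 2 gives 20 mg/kg.
compound 3 `CC(C)C(C)(C)/N=C(\NC#N)Nc1cccnc1` — in this assay compound 3 gives 1 mg/kg.

Compound 3 has the lowest of the two numbers shown; its nearest neighbour is compound 2, with a 20-fold lower number from compound 2 to compound 3 (1.30 log units; beyond the scatter). The other two steps point the same way: an at least 2.5-fold lower number from compound 1 to compound 2 (0.39 log units; beyond the scatter) and an at least 50-fold lower number from compound 1 to compound 3 (1.69 log units; beyond the scatter). Within the measured set, lengthening or branching the group on the double-bonded nitrogen has always lowered the number, and the 1,1,2-trimethylpropyl group gave the largest gain.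

Compound 4 `N#CN/C(=N\Cc1ccco1)Nc1cccnc1` differs from compound 3 by (furan-2-yl)methyl in place of 1,1,2-trimethylpropyl on a double-bonded nitrogen. Within the data shown here, no measured step covers a (furan-2-yl)methyl group, so the expectation rests on the step from propyl to 1,1,2-trimethylpropyl, which was large, and on the assumption that giving up the 1,1,2-trimethylpropyl group surrenders part of that gain. A step upward in this assay is therefore expected, beyond the scatter but short of returning to the level of compound 2; the expected step is a 6.0-fold higher number from compound 3 to compound 4 (0.78 log units; beyond the scatter). Compound 4 is accordingly estimated at 6 mg/kg, with a range from 2 mg/kg to 25 mg/kg.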

Compound 4, minimum effective dose: 20 mg/kg
Beside the measured number, compound 4's estimate is 3.3-fold (0.52 log units) below it, and the stated range covers the measured number.
By their numbers in this assay, from the lowest: compound 3; then compounds 2 and 4 (each within the scatter of the next). At a limit, above all of these: compound 1.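

In this assay, the (furan-2-yl)methyl group on the double-bonded nitrogen does not hold the gain of the 1,1,2-trimethylpropyl group, although both groups have 6 heavy atoms (a 20-fold higher number from compound 3 to compound 4 (1.30 log units; beyond the scatter)). Among these compounds, this is the first change at this position that raises the number, and set against the propyl group the ring-bearing group makes no difference (no change at the digits printed from compound 2 to compound 4 (within the scatter)), so a larger group here does not by itself lower the number, and compound 4 goes against the trend seen in compounds 1 to 3. Compound 1 stands at a limit of the assay, so the remaining step (an at least 2.5-fold lower number from compound 1 to compound 4 (0.39 log units; beyond the scatter)) gives a bound and not a size: the limit of > 50 mg/kg in this assay, at which 1 of the 4 values shown sits.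

On these data alone, it remains open whether the number of compound 4 is tied to the ring oxygen, which a phenylmethyl or a thiophen-2-ylmethyl group at this place would help to test. As far as these compounds go, it is equally open whether the low number of compound 3 needs the whole 1,1,2-trimethylpropyl group or whether a tert-butyl or a cyclohexyl group would read the same.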